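The source may hold more compounds than are shown below. What is called first, only, known or untested is meant among the compounds shown, and "the series" means these compounds.

Measured in a functional assay on SK-MEL-28 cells (Homo sapiens) for inhibition, read by sulforhodamine B assay, with a stated time of 48 h; on this read-out higher numbers stand for weaker inhibition of growth and lower numbers for stronger inhibition of growth:
- compound 1, `O=C(Nc1cccc(-n2cc(-c3ccncc3)c(-c3ccc(Cl)c(O)c3)n2)c1)Nc1cccc(C(F)(F)F)c1`: compound 1 gives 4110 nM
- compound 2, `O=C(Nc1cccc(-n2cc(-c3ccncc3)c(-c3ccc(Cl)c(O)c3)n2)c1)Nc1ccc(Cl)c(Cl)c1`: compound 2 gives 1460 nM
- compound 3, `COc1cc(-c2nn(-c3cccc(NC(=O)Nc4ccc(Cl)c(C(F)(F)F)c4)c3)cc2-c2ccncc2)ccc1Cl`: compound 3 gives 1200 nM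

Compound 3 stands at the low end of the three numbers in this assay; its gap to compound 2 lies within the scatter, while its gap to compound 1 lies beyond it.

Compound 4 is `O=C(Nc1cccc(-n2cc(-c3ccncc3)c(-c3ccc(Cl)c(O)c3)n2)c1)Nc1ccc(Cl)c(C(F)(F)F)c1`. It differs from compound 3 by hydrogen in place of methyl on an oxygen on an aromatic ring, the urea-side 4-chloro-3-(trifluoromethyl)phenyl being kept.

For the measured compounds named here, the only measured step, a 2.8-fold lower number from compound 1 to compound 2 (0.45 log units; beyond the scatter), concerns the aryl on the urea nitrogen and not the oxygen substituent, so it does not bear on this change. Compounds 1 and 2 carry the hydroxy and compound 3 the methoxy, but each pair also differs on the urea aryl, so no direct reading of methoxy against hydroxy exists here. With nothing in the data pointing either way, the expectation is a step no larger than the scatter, no change at the digits printed from compound 3 to compound 4 (within the scatter). Compound 4 is therefore estimated at 1200 nM in this assay, with a range from 450 nM to 3200 nM.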

Compound 4, concentration for 50% growth inhibition: 978 nM
The estimate for compound 4 lay 1.2-fold (0.09 log units) above the measured number; the measured number falls inside the stated range.
By their numbers in this assay, from the lowest: compounds 4, 3 and 2 (each within the scatter of the next); then compound 1.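

In this assay, for the compounds shown here, hydroxy in place of methoxy with the 4-chloro-3-(trifluoromethyl)phenyl kept gives a 1.2-fold lower number from compound 3 to compound 4 (0.09 log units; within the scatter), the first direct reading at this oxygen, and it shows no change beyond the scatter. With the hydroxy held, trifluoromethyl in place of chloro on an aromatic carbon of the urea aryl gives a 1.5-fold lower number from compound 2 to compound 4 (0.17 log units; within the scatter), while chloro in place of hydrogen on an aromatic carbon gives a 4.2-fold lower number from compound 1 to compound 4 (0.62 log units; beyond the scatter), so among these compounds only the latter step on the urea aryl clears the scatter. No measurement of any property of these groups accompanies the growth numbers.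

Going by these compounds, how an ethoxy or an amine at this place would read stays open. Also open, on these data alone, is whether methoxy to hydroxy reads the same with 3,4-dichlorophenyl or 3-(trifluoromethyl)phenyl on the urea.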